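The source may report more compounds than this note shows. Statements on the series, on what has been measured and on what is new or still open speak of the compounds shown alone.

This piece follows one small structural edit among a few nitrile-bearing amides tested in a functional assay on KG-1 cells (Homo sapiens) for cytotoxicity, read by luminescence and CellTiter-Glo, with a stated time of 3 days (on this read-out lower numbers stand for stronger inhibition and higher numbers for weaker inhibition), as a measure of cell killing. The starting point, compound 2 (`N#Cc1ccc(NC(=O)c2cc(Br)c3cccnc3c2O)cc1`), has no place on the scale. The result for compound 2 reads "not determined" (no result reported), and there is no number to compare against. Two relatives do have numbers. Compound 1 (`N#Cc1ccc(NC(=O)c2ccc3cccnc3c2O)c(F)c1`) gives 3260 nM as its half-maximal inhibitory concentration, and compound 3 (`Cc1cccc(C(=O)Nc2ccc(C#N)cc2)c1O`) gives 8980 nM on the same read-out, which makes compound 1 the stronger of the two.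

The compound still awaiting measurement is compound 4 (`N#Cc1ccc(NC(=O)c2ccc3cccnc3c2O)cc1`). The edit runs hydrogen in place of bromo on an aromatic carbon and amounts to hydrogen in place of bromo on an aromatic carbon, para to a hydroxy group. Within the data shown here, with nothing measured on the starting side, the size of this step in this assay cannot be read from the data, and no measured pair shows what losing the bromo does. The working expectation is therefore no step beyond the scatter, with neither direction favoured. The estimate leans on compound 1 (3260 nM), whose structure looks closest, while compound 3 (8980 nM) marks the weaker side. Compound 4 is expected to give about 3500 nM within an estimated range of 1200 nM to 10000 nM once it is measured.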

Compound 4, half-maximal inhibitory concentration: 2320 nM
For compound 4 the middle estimate is 1.5-fold (0.18 log units) above the measured one, and the stated range covers the measured number.
By their numbers in this assay, from the lowest: compounds 4 and 1 (each within the scatter of the next); then compound 3.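

Replacing fluoro with hydrogen on an aromatic carbon gives a 1.4-fold lower number from compound 1 to compound 4 (0.15 log units; within the scatter) in this assay, so this one pair shows no difference that can be told apart from ordinary repeat-to-repeat variation. That is the first direct comparison among these compounds, and it suggests that, on this shared core, the fluoro can be lost without a measurable change in this cell-killing read-out. The bromo question stays unanswered, however: compound 2 has no number, so the step from compound 2 to compound 4 cannot be read, and no other measurement here helps to explain the closeness of compound 1 and compound 4.

Going by these compounds, it remains open how the number would respond if the aromatic carbon that carries bromo in compound 2 held chloro, an amine or a carboxylic acid instead. Among these compounds, compound 1 and compound 4 are also only a single pair, so it is unknown whether the same exchange of fluoro for hydrogen would behave alike on a different core.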